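Amide aryl exchange on a shared core, paw edema inhibition

The compounds below may be only part of what the source reports. "The series", "measured", "known", "first", "only" and "open" are said of these compounds alone.

Compound 1 `O=C(Nc1ccccc1)c1c(O)c2cccnc2n(-c2ccccc2)c1=O` in a functional assay on the whole organism for inhibition, with Rattus norvegicus as the target, read by paw edema, at a dose of 100 mg/kg by the oral route; a lower number here means less inhibition, a higher number more inhibition at the dose given (going by the name of the read-out): 4.6%
Compound 2 `COc1ccc(NC(=O)c2c(O)c3cccnc3n(-c3ccccc3)c2=O)cc1` in this assay: 0.3%
Compound 3 `O=C(Nc1cccnc1)c1c(O)c2cccnc2n(-c2ccccc2)c1=O` in this assay: 30.3%

Compound 3 stands highest of the three: a number 25.7 percentage points higher from compound 1 to compound 3 (beyond the scatter) and a number 30 percentage points higher from compound 2 to compound 3 (beyond the scatter), both modest steps beyond the scatter, while a number 4.3 percentage points lower from compound 1 to compound 2 (within the scatter) lies within it. Compound 4 `O=C(Nc1cnccn1)c1c(O)c2cccnc2n(-c2ccccc2)c1=O` differs from compound 3 only in the group on the amide-type nitrogen: pyrazin-2-yl in place of pyridin-3-yl on an amide-type nitrogen. Among the measured compounds shown here, no measured step exchanges one nitrogen-containing six-membered ring for another; the two steps that bear on it show that replacing phenyl or 4-methoxyphenyl there by pyridin-3-yl raised the read-out modestly. For compound 4 a step of about a number 5.3 percentage points lower from compound 3 to compound 4 (within the scatter) is therefore expected, within the scatter. Compound 4 is estimated at 25%, with a range of 5% to 50%.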

Compound 4, a percentage reported as inhibition, in the whole organism at one dose (the size of the read-out at that dose, not a potency): 29.6%
Compound 4: the middle estimate sits 4.6 percentage points below what was measured; the measured number falls inside the stated range.
By their numbers in this assay, from the lowest: compounds 2 and 1 (each within the scatter of the next); then compounds 4 and 3 (each within the scatter of the next).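

In this assay, pyrazin-2-yl on the amide-type nitrogen reads level with pyridin-3-yl (a number 0.7 percentage points lower from compound 3 to compound 4 (within the scatter)), so the second ring nitrogen counted under this exchange leaves the number unmoved. Against the two benzene-based groups, pyrazin-2-yl also gives a rise (a number 25 percentage points higher from compound 1 to compound 4 (beyond the scatter); a number 29.3 percentage points higher from compound 2 to compound 4 (beyond the scatter)). The gain at this position is therefore not confined to pyridin-3-yl.

No measurement on hand explains why these two rings stand above phenyl and 4-methoxyphenyl. Open too, on these data alone, is what an amine or carboxylic acid on the ring, or a saturated piperidine ring on this nitrogen, would give.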